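Hydroxy to methoxy: from compound 1 to compound 4

A few compounds are considered here, and "the series" means these few. Any claim that something is new, unique, unknown or untested is made for them only; others in the source may bear on it.

For the measured compounds named here, in a functional assay on HCT-116 cells (Homo sapiens) for cytotoxicity, read by resazurin assay, with a stated time of 48 h (on this read-out higher numbers stand for an effect only at larger amounts of compound and lower numbers for an effect already at smaller amounts), compound 1 `O=C(Nc1ccc(Sc2nc3ccccc3s2)c(Cl)c1)c1cccc(Br)c1O` gives 12000 nM and stands level with the two other compounds measured so far. Compound 2 `COc1ccc(S(=O)(=O)Nc2ccc3oc(-c4ccc(NS(=O)(=O)c5cc(F)ccc5OC)cc4)nc3c2)cc1` gives 15000 nM and compound 3 `COc1ccc(S(=O)(=O)Nc2ccc3oc(-c4ccc(NC(=O)C5CCN(C(C)=O)CC5)cc4)nc3c2)cc1` gives 15000 nM on the same read-out, so all three lie within the usual scatter of one another.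

Compound 4 `COc1c(Br)cccc1C(=O)Nc1ccc(Sc2nc3ccccc3s2)c(Cl)c1` keeps the structure of compound 1 except in one place, methyl in place of hydrogen on an oxygen on an aromatic ring and this turns hydroxy into methoxy. Going by the values given here, no measured pair shows this change directly. Among the compounds with values here, the one measured step, no change at the digits printed from compound 2 to compound 3 (within the scatter) exchanges whole groups on a different core, so it is only a loose guide, though it does show the numbers staying flat across a much bigger edit. With nothing to argue a direction, the expected result is a 1.3-fold higher number from compound 1 to compound 4 (0.10 log units; within the scatter) and no shift beyond the scatter is foreseen. The estimate for compound 4 is 15000 nM and the expected range runs from 6000 nM to 40000 nM.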

Compound 4, half-maximal effective concentration: 8500 nM
Beside the measured number, compound 4's estimate is 1.8-fold (0.25 log units) above it; measured number inside the range.
By their numbers in this assay, from the lowest: compounds 4, 1, 2 and 3 (each within the scatter of the next).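

Replacing the hydrogen on this oxygen with methyl, which turns hydroxy into methoxy, gives a 1.4-fold lower number from compound 1 to compound 4 (0.15 log units; within the scatter) in this assay. For the compounds shown here, this is the first direct reading of this change on the core of compound 1, and it shows that the read-out does not separate the two compounds. The hydroxy hydrogen can therefore be replaced by methyl here with the number staying within the scatter, but nothing available explains this result.

A single small step leaves open what larger or different groups on this oxygen would do, such as ethyl, a longer chain or a chain ending in an amine. It also leaves open whether the same change would read the same way on another core, or with a carboxylic acid in place of the hydroxy.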